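Toward compound 4: trifluoroethyl to ethyl

The source may hold more compounds than are shown below. What is called first, only, known or untested is meant among the compounds shown, and "the series" means these compounds.

Measured in a toxicity assay on Vero cells (Chlorocebus sabaeus) for cytotoxicity, read by MTT assay; on this read-out lower numbers stand for stronger inhibition and higher numbers for weaker inhibition:
- compound 1 `CCCCNS(=O)(=O)c1ccc(C(=O)Nc2sccc2C(=O)NC(=O)OC)cc1`: 29.5 ug/mL
- compound 2 `O=C(NC(=O)c1ccsc1NC(=O)c1ccc(S(=O)(=O)N2CCCCC2)cc1)OCC(F)(F)F`: "nd" (no result reported)
- compound 3 `O=C(NC(=O)c1ccsc1NC(=O)c1ccc(S(=O)(=O)N2CCOCC2)cc1)OCC(F)(F)F`: "nd" (no result reported)

Compound 2 has no number on this read-out, so its standing in the series is open. Within the data shown here, compound 3 shares that gap, and no step between measured compounds exists. Compound 4 `CCOC(=O)NC(=O)c1ccsc1NC(=O)c1ccc(S(=O)(=O)N2CCCCC2)cc1` has not yet been measured and is the close partner of compound 2.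

The change is methyl in place of trifluoromethyl on a saturated chain carbon bound to an oxygen next to a carbonyl group, with methyl in place of trifluoromethyl on a saturated chain carbon bound to an oxygen next to a carbonyl group. Cut one bond further out, it reads 2,2,2-trifluoroethyl to ethyl.

With no measured reference for this change, no step beyond the scatter is expected in this assay, and no direction is assumed. Among the measured compounds shown here, the only numerical anchor is compound 1 (29.5 ug/mL), which differs from compound 4 in more than one place, so the range stays wide. For compound 4 the expected value is 28 ug/mL (estimated range 9 ug/mL to 85 ug/mL).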

Compound 4, half-maximal inhibitory concentration: 18.6 ug/mL
Compound 4: middle estimate off by 1.5-fold (0.18 log units), on the high side, within the range that was stated.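

Among these compounds, compound 2 has no reported value in this assay, so no step to compound 4 can be read. On these data alone, the effect of 2,2,2-trifluoroethyl to ethyl on this read-out therefore stays open, as does the standing of compound 2 and compound 3 in the series. No supporting evidence bears on the value of compound 4.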